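A few compounds are considered here, and "the series" means these few. Any claim that something is new, unique, unknown or untested is made for them only; others in the source may bear on it.

The measured compounds and their values:

Compound 1, `Cc1ccc(NC(=S)NC(=O)c2ccc(OCc3cccc(F)c3)cc2)cc1-c1nc2ccccc2[nH]1`, gives 55300 nM in a functional assay on HT-29 cells (Homo sapiens) for inhibition, read by MTT assay, with a stated time of 48 h; on this read-out higher numbers stand for weaker inhibition and lower numbers for stronger inhibition.
Compound 2, `Cc1ccc(NC(=S)NC(=O)c2ccc(OCc3ccccc3Cl)cc2)cc1-c1nc2ccccc2[nH]1`, gives 23700 nM in this assay.
Compound 3, `Cc1ccc(NC(=O)NC(=O)c2ccc(OCc3cccc(F)c3)cc2)cc1-c1nc2ccccc2[nH]1`, gives 38200 nM in this assay.

Compounds 1 and 2 share a core and differ in one place: 2-chlorophenyl in place of 3-fluorophenyl on a saturated chain carbon bound to an oxygen on an aromatic ring. That change made a 2.3-fold lower number from compound 1 to compound 2 (0.37 log units; beyond the scatter), a modest step that lies beyond the scatter. Compound 3 has a different core; how its core differs from that of compound 1 is not broken down here. Its value stands within the scatter of compound 1 and within the scatter of compound 2, so no order among these three can be read from the numbers.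

Compound 4, `Cc1ccc(NC(=O)NC(=O)c2ccc(OCc3ccccc3Cl)cc2)cc1-c1nc2ccccc2[nH]1`, has not yet been measured in this assay. It differs from compound 3 in one place: 2-chlorophenyl in place of 3-fluorophenyl on a saturated chain carbon bound to an oxygen on an aromatic ring. This is the same change that was made from compound 1 to compound 2, at the same place, on the other core. Among the measured compounds shown here, with only one measured example of this change, the expectation for compound 4 rests on that single step. Compound 4 is estimated at 17000 nM, which would mean an expected step of a 2.2-fold lower number from compound 3 to compound 4 (0.35 log units; beyond the scatter), close in size to the step from compound 1 to compound 2, because compound 3 starts at 38200 nM and the earlier step was a 2.3-fold lower number from compound 1 to compound 2 (0.37 log units; beyond the scatter). The expected range for compound 4 runs from 7000 nM to 40000 nM.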

Compound 4, half-maximal inhibitory concentration: 9010 nM
Compound 4: middle estimate off by 1.9-fold (0.28 log units), on the high side; the measured number falls inside the stated range.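

In this assay, putting 2-chlorophenyl in place of 3-fluorophenyl gave a 4.2-fold lower number from compound 3 to compound 4 (0.63 log units; beyond the scatter), the same direction as on the other core, and the two steps do not differ in size once the scatter of such measurements is allowed for: the same change on two cores in this assay, a 2.3-fold lower number (0.37 log units; beyond the scatter) from compound 1 to compound 2 and a 4.2-fold lower number (0.63 log units; beyond the scatter) from compound 3 to compound 4, 1.8-fold (0.26 log units) apart, within the scatter of two such steps. The second step looks larger, but the numbers give no ground for saying that one core responds more strongly than the other, so the change can be said to have carried over in both direction and size. This rests on just two pairs of compounds and one exchange of groups at one place, so it does not show that the step would hold on any further core or for any other group.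

The two groups differ both in the halogen and in where it sits on the ring, and the compounds shown do not separate these two differences. On these data alone, it also remains open how an unsubstituted phenyl, a phenyl carrying an amine or a carboxylic acid, or a longer chain in place of the benzyl link would behave on a saturated chain carbon bound to an oxygen on an aromatic ring.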